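The source may report more compounds than this note shows. Statements on the series, on what has been measured and on what is new or still open speak of the compounds shown alone.

Measured compounds:
Compound 1 `Oc1ccc(-c2cc(-c3cccs3)cc(-c3cccc(O)c3)n2)cc1` gives 85.7% in an assay on isolated protein for inhibition of DNA topoisomerase 1 (Homo sapiens), with a stated time of 30 min, tested at 100 uM; a higher number here means a stronger effect of the compound at the concentration tested, a lower number a weaker effect.
Compound 2 `Oc1ccccc1-c1cc(-c2ccsc2)cc(-c2ccccc2O)n1` gives 0%.
Compound 3 `Oc1cccc(-c2cc(-c3ccsc3)cc(-c3ccccc3O)n2)c1` gives 10.2%.

Compound 3 stands second highest of the three numbers in this assay; compound 2 lies lower, beyond the scatter, and compound 1 lies far higher. Compound 4 `Oc1ccc(-c2cc(-c3ccsc3)cc(-c3cccc(O)c3)n2)cc1` differs from compound 3 in one place: 4-hydroxyphenyl in place of 2-hydroxyphenyl on an aromatic carbon. Among the measured compounds shown here, the one measured step that bears on this change is a number 10.2 percentage points higher from compound 2 to compound 3 (beyond the scatter), where the 2-hydroxyphenyl likewise left. Compound 1, which carries no 2-hydroxyphenyl at all, gives 85.7%. A rise beyond the scatter is therefore expected, a number 59.8 percentage points higher from compound 3 to compound 4 (beyond the scatter). Compound 4 is estimated at 70%, with a range from 35% to 95%.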

Compound 4, a percentage reported as inhibition, at one concentration (the size of the read-out at that concentration, not a potency): 17.1%
Estimate against measurement, compound 4: 52.9 percentage points above, and the stated range ends above it.
By their numbers in this assay, from the lowest: compound 2; then compounds 3 and 4 (each within the scatter of the next); then compound 1.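

In this assay, 4-hydroxyphenyl in place of 2-hydroxyphenyl gives a number 6.9 percentage points higher from compound 3 to compound 4 (within the scatter) and so does not separate the two compounds, which shows that losing the 2-hydroxyphenyl from this position is not enough to reach the number of compound 1. Thiophen-3-yl in place of thiophen-2-yl gives a number 68.6 percentage points lower from compound 1 to compound 4 (beyond the scatter) and so places the large gap at the thiophene attachment. No available evidence bears on the reason for this gap.

The compounds shown leave open whether thiophen-2-yl would hold up with a 2-hydroxyphenyl at this position. They also leave open how an aminophenyl group there, or a furan in place of the thiophene, would read.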